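This account rests on a few compounds, and the source may have more. Where it says the series, first, only, none or still open, it means among the compounds named here.

Compound 1, `C#CCn1c(=N)sc2cc(OC(F)(F)F)ccc21`, gives in a functional assay on the whole organism with Rattus norvegicus as the target (a lower number here means that less compound is needed, a higher number that more compound is needed for the effect), a value of 4 mg/kg.
Compound 2, `N=c1sc2cc(OC(F)(F)F)ccc2n1CC(=O)O`, gives in this assay only a limit of the assay, > 10 mg/kg.
Compound 3, `C[S+]([O-])Cn1c(=N)sc2cc(OC(F)(F)F)ccc21`, gives in this assay a value of 2.3 mg/kg.

Among the two numbers shown, compound 3 has the lowest; its nearest neighbour is compound 1, and the gap between them is a 1.7-fold lower number from compound 1 to compound 3 (0.24 log units; within the scatter). The third entry, for compound 2, is a limit rather than a number, as the limit of > 10 mg/kg in this assay, at which 1 of the 3 values shown sits, records.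

Compound 4, `CSCCCn1c(=N)sc2cc(OC(F)(F)F)ccc21`, has not been measured in this assay. It differs from compound 3 in one place: a group of 4 heavy atoms (3 carbon, 1 sulfur; no ring) in place of a group of 3 heavy atoms (1 carbon, 1 oxygen, 1 sulfur; no ring), on a saturated chain carbon bound to an aromatic nitrogen.

Within the data shown here, two measured steps touch this same place. The exchange of a two-carbon group for the sulfur-containing group gave a 1.7-fold lower number from compound 1 to compound 3 (0.24 log units; within the scatter), while the exchange of a carboxy group for it gave an at least 4.3-fold lower number from compound 2 to compound 3 (0.63 log units; beyond the scatter). Neither step swaps in a 2-(methylsulfanyl)ethyl group, so neither tells directly about compound 4. Among the measured compounds shown here, the one clear step concerns a carboxy group, which compound 4 does not carry. The step from compound 3 to compound 4 is therefore expected to stay within the scatter, as a 1.3-fold higher number from compound 3 to compound 4 (0.12 log units; within the scatter).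

Compound 4 is estimated to give 3 mg/kg in this assay, within a range from 1.2 mg/kg to 8 mg/kg.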

Compound 4, dose for half-maximal effect: 4.2 mg/kg
Compound 4: the middle estimate sits 1.4-fold (0.15 log units) below what was measured; low and high end bracket the measured number.
By their numbers in this assay, from the lowest: compounds 3, 1 and 4 (each within the scatter of the next). At a limit, above all of these: compound 2.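

The new chain shows that this place, on a saturated chain carbon bound to an aromatic nitrogen, accepts a 2-(methylsulfanyl)ethyl group in this assay without a change that can be told from the scatter: a 1.8-fold higher number from compound 3 to compound 4 (0.26 log units; within the scatter), and a 1.1-fold higher number from compound 1 to compound 4 (0.02 log units; within the scatter). Ethynyl, the sulfur-and-oxygen group of compound 3 and this longer chain therefore cannot be ranked here, and the carboxy group now stands apart from a second and differently built chain, as seen in an at least 2.3-fold lower number from compound 2 to compound 4 (0.37 log units; beyond the scatter). The size of that step has no firm end, as compound 2 is recorded only as a limit: the limit of > 10 mg/kg in this assay, at which 1 of the 4 values shown sits.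

The compounds shown do not separate the role of the sulfur from that of chain length, since compound 1 carries no sulfur and still lies within the scatter of compound 3 and compound 4, so a plain butyl chain at this place would be the telling comparison. From the compounds shown here alone, it also remains open how an amine, a ring or a chain longer than 2-(methylsulfanyl)ethyl would behave here.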